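Swapping Ethyl for Methoxy Where Only Limits Are Known

This account rests on a few compounds, and the source may have more. Where it says the series, first, only, none or still open, it means among the compounds named here.

Compound 1 `CCCc1nc(Br)c2c(Br)nnc(O)n12`: in a functional assay for inhibition, with Homo sapiens as the target (on this read-out higher numbers stand for weaker inhibition and lower numbers for stronger inhibition), compound 1 gives 48000 nM.
Compound 2 `CCCc1ncc2cnnc(O)n12`: in this assay compound 2 gives > 48000 nM, a limit of the assay rather than a number.
Compound 3 `CCCc1nc(Br)c2cnnc(O)n12`: in this assay compound 3 gives > 48000 nM, again a limit of the assay.

Compound 3 therefore stands only at the edge of what this assay can report, without an exact number. Two of the three values sit at that edge (the limit of > 48000 nM in this assay, at which 2 of the 3 values shown sit). The measured steps that reach compound 3, a number no lower from compound 1 to compound 3 (the limit leaves the size open) and a step that the two limits leave unreadable from compound 2 to compound 3, both run into the limit, so their sizes cannot be read. Compound 4 `COCc1nc(Br)c2cnnc(O)n12` differs from compound 3 by methoxy in place of ethyl on a saturated chain carbon bound to an aromatic carbon. No measured step touches this chain, so nothing shown points to a readable change. Compound 4 is expected to remain at the limit, with no step beyond the scatter: a step that the limit leaves unreadable from compound 3 to compound 4. The estimate for compound 4 is 70000 nM, expected to lie between 30000 nM and 200000 nM.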

Compound 4, half-maximal inhibitory concentration: > 48000 nM
Compound 4: a limit, no number (the forecaster's own chance of this, stated with the estimate: 80%); the middle value does not contradict the limit.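

Compound 3 and compound 4 both stay at a limit of the assay rather than a number, so no new step can be read. Whether methoxy in place of ethyl changes inhibition at all stays open, with most values at one edge: the limit of > 48000 nM in this assay, at which 3 of the 4 values shown sit.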